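The source may hold more compounds than are shown below. What is called first, only, known or untested is meant among the compounds shown, and "the series" means these compounds.

Notes on the series. Compound 1 `O=C(/C=C/c1ccccc1)Nc1ccc2c(c1)COC2=O` and compound 2 `O=C(/C=C/c1ccco1)Nc1ccc2c(c1)COC2=O` share one core and differ only in the aryl group on the double-bonded chain carbon. In a functional assay on cells (T-cell, Mus musculus) for inhibition (on this read-out higher numbers stand for weaker inhibition and lower numbers for stronger inhibition), compound 1 gives 7240 nM, and in this assay compound 2 gives 9000 nM; the two values lie within the scatter of each other, so neither is placed ahead of the other, and the step of a 1.2-fold higher number from compound 1 to compound 2 (0.09 log units; within the scatter) carries no real change. Compound 3 `O=C(/C=C/c1ccccn1)Nc1ccc2c(c1)COC2=O` is not yet measured. It differs from compound 2 as follows: pyridin-2-yl in place of furan-2-yl on a double-bonded chain carbon bound to a double-bonded chain carbon. Going by the values given here, the only measured step that bears on this is the aryl exchange a 1.2-fold higher number from compound 1 to compound 2 (0.09 log units; within the scatter), which stayed within the scatter, so for compound 3 in this assay the step of a 1.1-fold lower number from compound 2 to compound 3 (0.05 log units; within the scatter) is expected to stay within the scatter as well. For compound 3 the estimated value in this assay is 8000 nM, with a range from 3000 nM to 20000 nM.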

Compound 3, half-maximal inhibitory concentration: 17900 nM
For compound 3 the middle estimate is 2.2-fold (0.35 log units) below the measured one; the measured number falls inside the stated range.
By their numbers in this assay, from the lowest: compounds 1, 2 and 3 (each within the scatter of the next, the first and the last beyond it).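

In this assay, going by these compounds alone, the change to pyridin-2-yl on a double-bonded chain carbon bound to a double-bonded chain carbon gives the first step at this position that lies beyond the scatter (a 2.5-fold higher number from compound 1 to compound 3 (0.39 log units; beyond the scatter)), and that step is modest. The other step stays within the scatter (a 2.0-fold higher number from compound 2 to compound 3 (0.30 log units; within the scatter)), so pyridin-2-yl separates from phenyl but not from furan-2-yl. Within the data shown here, the position therefore tolerates all three aromatic rings without a large step, yet it is not wholly indifferent to the exchange, and the one step beyond the scatter points towards weaker inhibition.

From the compounds shown here alone, whether a saturated cyclohexyl ring, or a phenyl ring carrying an amine or a carboxylic acid, would move the number down or up remains open. Nothing given here accounts for the pyridin-2-yl result.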